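The source may report more compounds than this note shows. Statements on the series, on what has been measured and on what is new or still open speak of the compounds shown alone.

Compound 1 `Cc1cn(Cc2ccc(O)c(C(C)C)c2)c2ccc(OCC(=O)O)cc12` and compound 2 `Cc1cn(Cc2ccc(O)c(C(C)(C)C)c2)c2ccc(OCC(=O)O)cc12` share one core and differ only in the group ortho to the hydroxy group. In an assay on HeLa cells for displacement of a labelled ligand from thyroid hormone receptor beta (Homo sapiens) (on this read-out higher numbers stand for weaker inhibition and lower numbers for stronger inhibition), compound 1 gives 0.38 nM; in this assay compound 2 gives 0.3 nM. The step of a 1.3-fold lower number from compound 1 to compound 2 (0.10 log units; within the scatter) shows that methyl in place of hydrogen there changes little. Compound 2 stands at one end of the two numbers, with compound 1 within the scatter of it. Compound 3 `Cc1cn(Cc2ccc(O)c(CC3CCCCC3)c2)c2ccc(OCC(=O)O)cc12` carries cyclohexylmethyl in place of tert-butyl on an aromatic carbon. Within the data shown here, only that single small step bears on this larger change, so any shift in this assay is expected to stay modest. The step of a 2.0-fold higher number from compound 2 to compound 3 (0.30 log units; within the scatter) is expected, and compound 3 is estimated at 0.6 nM, between 0.15 nM and 2.5 nM.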

Compound 3, inhibition constant: 1.11 nM
Estimate against measurement, compound 3: 1.9-fold (0.27 log units) below; the measured number falls inside the stated range.
By their numbers in this assay, from the lowest: compounds 2 and 1 (each within the scatter of the next); then compound 3.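

Among these compounds, on the aromatic carbon ortho to a hydroxy group, cyclohexylmethyl is the first change to move the number beyond the scatter in this assay, giving a 3.7-fold higher number from compound 2 to compound 3 (0.57 log units; beyond the scatter) and a 2.9-fold higher number from compound 1 to compound 3 (0.47 log units; beyond the scatter). Both steps are modest, so this position accepts a group carrying a six-membered non-aromatic ring with inhibition kept at a low nanomolar number. Nothing available explains the shift. Open, from the compounds shown here alone, is whether the ring itself or its methylene link sets the step. Also open, going by these compounds, is how a phenyl, a benzyl or an amine-bearing chain on this carbon would read.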